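Pyridine ring and loss of methyl: compound 4 expected

The compounds below may be only part of what the source reports. "The series", "measured", "known", "first", "only" and "open" are said of these compounds alone.

Compound 1 `CCCCc1nc(Cl)c(COC(=O)c2cccc(CO[N+](=O)[O-])c2)n1Cc1ccc(-c2ccccc2-c2nn[nH]n2)cc1` gives 100% in a functional assay on the whole organism (aorta, strain Wistar) with Rattus norvegicus as the target; a lower number here means a smaller maximal response, a higher number a larger maximal response. Compound 2 `CCCCc1nc(Cl)c(COC(=O)c2cccc(C(C)O[N+](=O)[O-])c2)n1Cc1ccc(-c2ccccc2-c2nn[nH]n2)cc1` gives 47%. Compound 3 `CCCCc1nc(Cl)c(COC(=O)c2c(C)ccc(CO[N+](=O)[O-])c2C)n1Cc1ccc(-c2ccccc2-c2nn[nH]n2)cc1` gives 100%.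

Compound 2 stands lowest of the three, and compound 1 and compound 3 each sit well above it. Compound 4 `CCCCc1nc(Cl)c(COC(=O)c2cccc(CO[N+](=O)[O-])n2)n1Cc1ccc(-c2ccccc2-c2nn[nH]n2)cc1` differs from compound 2 by one exchange: 6-((nitrooxy)methyl)pyridin-2-yl in place of 3-(1-(nitrooxy)ethyl)phenyl on a carbonyl carbon. The step of a number 53 percentage points lower from compound 1 to compound 2 (beyond the scatter) bears directly on this, since it is the very methyl that leaves again in compound 4; compound 3, which also carries the unbranched nitrooxymethyl group, matches compound 1. On these data alone, the pyridine ring is untested here, so the expected step of a number 38 percentage points higher from compound 2 to compound 4 (beyond the scatter) is taken as large and upward with a wide range. Compound 4 is therefore expected to give about 85%, between 55% and 100%.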

Compound 4, largest response reached (Emax), in percent of the reference or control that the assay uses: 100%
The estimate for compound 4 lay 15 percentage points below the measured number, within the range that was stated.
By their numbers in this assay, from the lowest: compound 2; then compounds 1, 3 and 4 (each within the scatter of the next).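

In this assay, putting 6-((nitrooxy)methyl)pyridin-2-yl in place of 3-(1-(nitrooxy)ethyl)phenyl on the carbonyl carbon gives a number 53 percentage points higher from compound 2 to compound 4 (beyond the scatter). Exchanging 3-((nitrooxy)methyl)phenyl for the same pyridine group gives no change at the digits printed from compound 1 to compound 4 (within the scatter), so at this position the ring with a hetero atom matches the carbon-only ring in this read-out. No measurement here accounts for either step. On these data alone, whether the extra methyl would lower the response on the pyridine ring as it does on the phenyl ring remains open. So does the effect of a longer chain or an amine in place of the nitrooxy group.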